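A few compounds are considered here, and "the series" means these few. Any claim that something is new, unique, unknown or untested is made for them only; others in the source may bear on it.

Measured in a functional assay on cells (Cancer cell lines, Homo sapiens) for inhibition; on this read-out lower numbers stand for stronger inhibition of growth and higher numbers for weaker inhibition of growth:
Compound 1 `Cc1cc(-c2nc3sc(C)cn3c2/C=N/NC(=N)N)c(C)s1`: 32400 nM
Compound 2 `Cc1cn2c(/C=N/Nc3ccccn3)c(-c3ccc(Cl)c([N+](=O)[O-])c3)nc2s1`: 39800 nM
Compound 3 `N=C(N)N/N=C/c1c(-c2cc(Cl)sc2Cl)nc2n1CCS2`: 20000 nM

These three values lie within the scatter of one another, so compound 3, at 20000 nM, stands level with the other two. Compound 4 `Cc1cc(-c2nc3n(c2/C=N/NC(=N)N)CCS3)c(C)s1` has 2,5-dimethylthiophen-3-yl in place of 2,5-dichlorothiophen-3-yl on an aromatic carbon. Within the data shown here, no measured pair isolates this change. Compound 1, which also carries 2,5-dimethylthiophen-3-yl, gives 32400 nM, so no step beyond the scatter is expected in this assay. The expected change is a 1.3-fold higher number from compound 3 to compound 4 (0.10 log units; within the scatter). For compound 4 the estimated value is 25000 nM, within an expected range of 12000 nM to 50000 nM.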

Compound 4, concentration for total growth inhibition: 38000 nM
Compound 4: middle estimate off by 1.5-fold (0.18 log units), on the low side; the range from low to high includes it.
By their numbers in this assay, from the lowest: compounds 3, 1, 4 and 2 (each within the scatter of the next).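

Where the two compounds differ in one place only, 2,5-dimethylthiophen-3-yl in place of 2,5-dichlorothiophen-3-yl on the aromatic carbon gives a 1.9-fold higher number from compound 3 to compound 4 (0.28 log units; within the scatter) in this assay. This direct reading puts the two groups level at this position, which compound 1, with its different core, could not show. Nothing at hand speaks to why they read alike. The compounds shown leave open whether this position tolerates groups other than substituted thiophenes, such as a morpholine or a carboxylic acid on the ring, and whether any such group would move growth inhibition beyond the scatter.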